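The source may hold more compounds than are shown below. What is called first, only, known or untested is meant among the compounds shown, and "the series" means these compounds.

The study concerns inhibition of a cytokine–receptor pair, followed in an assay on isolated protein (Mus musculus) for inhibition of IL15-IL15 receptor (Homo sapiens), read by resazurin assay, with stated times of 30 min and 2.5 days; a lower number here means a stronger inhibitor, a higher number a weaker inhibitor. Compound 1, `CCCOc1ccc(NC(=O)CSc2nnc(Cc3nn(C)c(=O)c4ccccc34)n2C)cc1`, is the starting point. In this assay compound 1 gives > 30000 nM, which is a limit of the assay and not a measured number. Compound 1 therefore stands at the limit of > 30000 nM in this assay, at which 1 of the 2 values shown sits. Compound 2, `CCCOc1ccc(NC(=O)CCCCCCCSc2nnc(Cc3nn(C)c(=O)c4ccccc34)n2C)cc1`, carries a longer chain to the same amide end; in this assay compound 2 gives 1600 nM, a value measured outright. Compound 3, `CN(C(=O)CSc1nnc(Cc2nn(C)c(=O)c3ccccc23)n1C)c1ccc(Cl)cc1Cl`, has not yet been measured in this assay. It differs from compound 1 in one place: (2,4-dichlorophenyl)(methyl)amino in place of (4-propoxyphenyl)amino on a carbonyl carbon. The short chain of compound 1 is retained, and only the amide end is altered. With compound 1 at a limit, a step can only be expected in the direction of a stronger inhibitor, and a change confined to the amide end is expected to give no more than a modest gain. The step from compound 1 to compound 3 is estimated at an at least 1.5-fold lower number from compound 1 to compound 3 (0.17 log units; that floor lies within the scatter). Compound 3 is expected to give about 20000 nM, with a likely range from 5000 nM to 60000 nM.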

Compound 3, half-maximal inhibitory concentration: > 30000 nM
Compound 3: a limit, no number (the forecaster's own chance of this, stated with the estimate: 50%); middle value at least 1.5-fold (0.17 log units) from the limit.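

In this assay compound 3 gives > 30000 nM, a limit of the assay and not a number. Compound 1 and compound 3 thus share one limit, and no step between them can be read: the limit of > 30000 nM in this assay, at which 2 of the 3 values shown sit.

The compounds shown leave open whether the (2,4-dichlorophenyl)(methyl)amino end would give a measurable value on the longer chain of compound 2.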